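Toward Compound 4 in the Alpha-1 Binding Series

This account rests on a few compounds, and the source may have more. Where it says the series, first, only, none or still open, it means among the compounds named here.

Measured compounds:
Compound 1 `CCCCOCCOC1CCN(c2nc(N)c3cc(OC)c(OC)cc3n2)CC1` gives 1.03 nM in an assay on brain for displacement of a labelled ligand from Adrenergic receptor alpha-1 (Rattus norvegicus); on this read-out lower numbers stand for stronger inhibition and higher numbers for weaker inhibition.
Compound 2 `CCOC(C)COC1CCN(c2nc(N)c3cc(OC)c(OC)cc3n2)CC1` gives 0.99 nM in this assay.
Compound 3 `COc1cc2nc(N3CCC(OCC(O)c4ccccc4)CC3)nc(N)c2cc1OC` gives 0.15 nM in this assay.

Compound 2 stands second highest of the three in this assay; compound 1 lies within the scatter of it, while compound 3 sits well apart (a 6.6-fold lower number from compound 2 to compound 3 (0.82 log units; beyond the scatter)). Compound 4 `COc1cc2nc(N3CCC(OCC(C)(O)c4ccccc4)CC3)nc(N)c2cc1OC` is not yet measured. It differs from compound 2 by 1-hydroxy-1-phenylethyl in place of 1-ethoxyethyl on a saturated chain carbon bound to an oxygen on a saturated carbon. Going by the values given here, the step that bears on it is the one from compound 2 to compound 3 (a 6.6-fold lower number from compound 2 to compound 3 (0.82 log units; beyond the scatter)), which also brings a phenyl ring and a hydroxy group into the same place; compound 4 adds a methyl beyond that. Compound 4 is therefore expected to show a lower number, a 4.0-fold lower number from compound 2 to compound 4 (0.60 log units; beyond the scatter), and is estimated at 0.25 nM, between 0.08 nM and 0.8 nM.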

Compound 4, inhibition constant: 0.62 nM
The estimate for compound 4 lay 2.5-fold (0.39 log units) below the measured number, within the range that was stated.
By their numbers in this assay, from the lowest: compound 3; then compounds 4, 2 and 1 (each within the scatter of the next).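

In this assay, methyl in place of hydrogen on a saturated chain carbon bound to an aromatic carbon, an oxygen on a saturated carbon and a saturated chain carbon gives a 4.1-fold higher number from compound 3 to compound 4 (0.62 log units; beyond the scatter), so this position responds to one added methyl. A phenyl ring and a hydroxy group together therefore do not ensure separation from the ethers: 1-hydroxy-1-phenylethyl gives a 1.6-fold lower number from compound 2 to compound 4 (0.20 log units; within the scatter) and a 1.7-fold lower number from compound 1 to compound 4 (0.22 log units; within the scatter). Nothing available explains this response. The compounds shown leave open how an ethyl in place of that methyl, or an amine in place of the hydroxy, would read.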